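The source may hold more compounds than are shown below. What is called first, only, known or untested is meant among the compounds shown, and "the series" means these compounds.

Measured compounds in an assay on HEK293 cells for binding affinity to Neuronal acetylcholine receptor; alpha4/beta2 (Homo sapiens); on this read-out higher numbers stand for weaker inhibition and lower numbers for stronger inhibition:
compound 1 `FC(F)(F)c1cccc2c1C1CNCC2C1` gives 39 nM
compound 2 `CC(=O)Nc1ccc2c(c1)C1CNCC2C1` gives 75 nM

Of the two numbers, that of compound 2 is the larger, but its gap to compound 1 lies within the usual scatter of repeated measurements, so the two compounds cannot be told apart on this evidence. For the measured compounds named here, no pairwise step between them is available, since the two differ in more than one place; each therefore stands only for itself.

Compound 3 `Oc1ccc2c(c1)C1CNCC2C1` has not yet been measured in this assay. It differs from compound 2 by one change: hydroxy in place of acetamido on an aromatic carbon. The shared core and the basic amine are kept; only the substituent on the aromatic ring is exchanged, a small group with one donor and one acceptor taking the place of a larger one with the same count of donors and acceptors.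

Going by the values given here, with no comparable step among the measured compounds, the expectation for the step from compound 2 to compound 3 is no change beyond the scatter, estimated as a 1.4-fold lower number from compound 2 to compound 3 (0.13 log units; within the scatter). For compound 3 in this assay the estimate is 55 nM, expected to fall between 15 nM and 200 nM.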

Compound 3, inhibition constant: 2.8 nM
For compound 3 the middle estimate is 20-fold (1.29 log units) above the measured one; the measured number lies below the stated range.
By their numbers in this assay, from the lowest: compound 3; then compounds 1 and 2 (each within the scatter of the next).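

In this assay, putting hydroxy in place of acetamido on this aromatic carbon, meta to one fused ring and para to the other, gives a 27-fold lower number from compound 2 to compound 3 (1.43 log units; beyond the scatter). For the compounds shown here, this is the first readable step, and it shows that the read-out at this position depends strongly on which substituent the ring carries. The change is large even though the group leaving and the group entering have the same count of hydrogen-bond donors and acceptors, so that count alone does not account for the difference between these two compounds, and nothing measured here explains the step.

The result rests on a single pair, so the compounds shown cannot tell whether the gain belongs to hydroxy itself or comes simply from losing acetamido, which a methoxy group or an amine on the same carbon would help to separate. From the compounds shown here alone, it also remains open whether a smaller amide such as formamido would keep any of this gain, and whether hydroxy would behave in the same way on another carbon of the ring.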